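Methoxy to hydroxy from compound 3 to compound 4

The compounds below may be only part of what the source reports. "The series", "measured", "known", "first", "only" and "open" are said of these compounds alone.

In a functional assay on SK-BR-3 cells (Homo sapiens) for cytotoxicity, read by CellTiter-Glo, with a stated time of 72 h (on this read-out lower numbers stand for stronger inhibition and higher numbers for weaker inhibition), compound 1 (`C=CCNC1=C2C[C@@H](C)C[C@H](OC)C(=O)[C@@H](C)/C=C(\C)[C@H](OC(N)=O)[C@@H](OC)/C=C\C=C(/C)C(=O)NC(=CC1=O)C2=O`) gives 450 nM and compound 2 (`CO[C@H]1C[C@H](C)CC2=C(NCCN(C)C)C(=O)C=C(NC(=O)/C(C)=C/C=C\[C@H](OC)[C@@H](OC(N)=O)/C(C)=C/[C@H](C)C1=O)C2=O`) gives 100 nM under the same conditions. Compound 3 (`CO/N=C1/[C@@H](OC)C[C@H](C)CC2=C(NCCN(C)C)C(=O)C=C(NC(=O)/C(C)=C/C=C\[C@H](OC)[C@@H](OC(N)=O)/C(C)=C/[C@@H]1C)C2=O`) gives 550 nM within the scatter of compound 1 and higher than compound 2. Compound 4 (`CO[C@H]1C[C@H](C)CC2=C(NCCN(C)C)C(=O)C=C(NC(=O)/C(C)=C/C=C\[C@H](OC)[C@@H](OC(N)=O)/C(C)=C/[C@H](C)/C1=N\O)C2=O`) differs from compound 3 by hydrogen in place of methyl on an oxygen with hydrogen in place of methyl on an oxygen, so methoxy to hydroxy. For the measured compounds named here, no measured step covers this change. Going by the values given here, the only measured step is a 4.5-fold lower number from compound 1 to compound 2 (0.65 log units; beyond the scatter) at another place and offers a scale only. A lean toward compound 2 at 100 nM suggests a lower number. The expected change is a 2.0-fold lower number from compound 3 to compound 4 (0.29 log units; within the scatter) in this assay and may stay near the scatter. For compound 4 the estimate is 280 nM with an expected range of 110 nM to 650 nM in this series.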

Compound 4, half-maximal inhibitory concentration: 95 nM
Compound 4: the middle estimate sits 2.9-fold (0.47 log units) above what was measured; the measured number lies below the stated range.
By their numbers in this assay, from the lowest: compounds 4 and 2 (each within the scatter of the next); then compounds 1 and 3 (each within the scatter of the next).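

On the oxygen whose other neighbour is the double-bonded nitrogen, the group matters: hydrogen in place of methyl gives a 5.8-fold lower number from compound 3 to compound 4 (0.76 log units; beyond the scatter) in this assay. With hydroxy, compound 4 at 95 nM lies within the scatter of compound 2 at 100 nM. No evidence bears on the cause of this step.

Only hydrogen and methyl are shown on this oxygen, so the effect of an ethyl group, a longer chain or a carboxylic acid there stays open. On these data alone, whether the step holds with the amine side chain of compound 1 also stays open.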